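This account rests on a few compounds, and the source may have more. Where it says the series, first, only, none or still open, it means among the compounds named here.

Compound 1 `COc1ccc(Nc2ncc3cc(S(=O)(=O)c4ccc(C)cc4)c(=O)n(C)c3n2)cc1`: 75000 nM
Compound 2 `Cc1ccc(S(=O)(=O)c2cc3cnc(Nc4ccc5[nH]ccc5c4)nc3n(C)c2=O)cc1`: 750 nM

In a functional assay on K562 cells (Homo sapiens) for inhibition, read by trypan blue exclusion, with a stated time of 72 h (on this read-out higher numbers stand for weaker inhibition and lower numbers for stronger inhibition), compound 2 gives 750 nM, the lower of the two numbers. Compound 3 `Cc1ccc(S(=O)(=O)c2cc3cnc(Nc4ccc5ncccc5c4)nc3n(C)c2=O)cc1` differs from it in one place: quinolin-6-yl in place of 1H-indol-5-yl on a nitrogen on an aromatic ring. Among the compounds with values here, one measured step bears on this place, a 100-fold lower number from compound 1 to compound 2 (2.00 log units; beyond the scatter). Within the data shown here, that step was large, so a swap here can shift the number strongly, yet no measured compound carries quinolin-6-yl. A moderate loss of inhibition in this assay is therefore expected, with wide uncertainty, and the expected step is a 3.3-fold higher number from compound 2 to compound 3 (0.52 log units; beyond the scatter). For compound 3 the estimated value is 2500 nM, with an expected range of 500 nM to 15000 nM.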

Compound 3, half-maximal inhibitory concentration: 10000 nM
Compound 3: the middle estimate sits 4.0-fold (0.60 log units) below what was measured; measured number inside the range.
By their numbers in this assay, from the lowest: compound 2; then compound 3; then compound 1.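

This position separates even two groups that each hold two aromatic rings: quinolin-6-yl in place of 1H-indol-5-yl gives a large loss in this assay (a 13-fold higher number from compound 2 to compound 3 (1.12 log units; beyond the scatter)). Yet quinolin-6-yl still improves on 4-methoxyphenyl (a 7.5-fold lower number from compound 1 to compound 3 (0.88 log units; beyond the scatter)), so the second ring helps in both compounds but does not alone match compound 2. The change also swaps a hydrogen-bond donor for an acceptor, but nothing measured here explains the loss. From the compounds shown here alone, whether that donor matters remains open, and an N-methylindol-5-yl group would test it. Going by these compounds, how a phenyl ring carrying an amine or a carboxylic acid would behave also remains open.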